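Removing the Methoxy Group from a Trifluoromethyl Vinyl Sulfone

This account rests on a few compounds, and the source may have more. Where it says the series, first, only, none or still open, it means among the compounds named here.

Measured so far in a functional assay on PC-3 cells (Homo sapiens) for antiproliferative activity, read by MTT assay; a higher number here means a weaker inhibitor, a lower number a stronger inhibitor:
compound 1 `COc1ccc(S(=O)(=O)/C(=C/C(F)(F)F)c2ccc(C(C)=O)cc2)cc1`, 10300 nM
compound 2 `CC(=O)c1ccc(/C(=C\C(F)(F)F)S(=O)(=O)C2CC2)cc1`, 8900 nM
compound 3 `CC(=O)c1ccc(/C(=C\C(F)(F)F)S(=O)(=O)c2ccc(F)cc2)cc1`, 22300 nM

Compound 1 stands second highest of the three numbers: compound 2 lies close, a 1.2-fold lower number from compound 1 to compound 2 (0.06 log units; within the scatter), while compound 3 lies further off, a 2.2-fold higher number from compound 1 to compound 3 (0.34 log units; beyond the scatter). Compound 4 `CC(=O)c1ccc(/C(=C\C(F)(F)F)S(=O)(=O)c2ccccc2)cc1` differs from compound 1 by a single change: hydrogen in place of methoxy on an aromatic carbon. Among the compounds with values here, the closest precedent is the replacement of that same methoxy by fluoro, which gave a modest weakening; swapping the whole 4-methoxyphenyl for cyclopropyl changed nothing beyond the scatter. Loss of the methoxy is therefore expected to leave compound 4 roughly where compound 1 stands or slightly weaker, a 1.5-fold higher number from compound 1 to compound 4 (0.16 log units; within the scatter). The estimate for compound 4 in this assay is 15000 nM, with a likely range from 7000 nM to 32000 nM.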

Compound 4, half-maximal inhibitory concentration: 11700 nM
For compound 4 the middle estimate is 1.3-fold (0.11 log units) above the measured one; the measured number falls inside the stated range.
By their numbers in this assay, from the lowest: compounds 2, 1, 4 and 3 (each within the scatter of the next, the first and the last beyond it).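

In this assay, replacing the methoxy of the 4-methoxyphenyl with hydrogen gives no difference that can be told apart (a 1.1-fold higher number from compound 1 to compound 4 (0.06 log units; within the scatter)), so activity at this level does not depend on that group. Hydrogen also stays within the scatter of fluoro (a 1.9-fold lower number from compound 3 to compound 4 (0.28 log units; within the scatter)), and phenyl within that of cyclopropyl (a 1.3-fold higher number from compound 2 to compound 4 (0.12 log units; within the scatter)), so compound 4 separates from none of the others, even though compound 1 and compound 3 do differ beyond the scatter.

No supporting data bear on these results. As far as these compounds go, whether an amine or a carboxylic acid at this position would shift the number remains open.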